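Notes on the shift from compound 3 to compound 4

The compounds below may be only part of what the source reports. "The series", "measured", "known", "first", "only" and "open" are said of these compounds alone.

Of the compounds shown here, three have been measured in a functional assay on PC-3 cells (Homo sapiens) for cytotoxicity, read by MTT assay, with a stated time of 48 h; a lower number here means a stronger inhibitor, a higher number a weaker inhibitor: compound 1 `CC1=NN(C(=O)CCc2ccccc2)C(c2cc(Br)ccc2O)C1` gives 16300 nM, compound 2 `CCN(CC)CC(=O)N1N=C(C)CC1c1ccccc1OC(C)=O` gives 51200 nM, and compound 3 `CC(C)CNCC(=O)N1N=C(c2cc3ccccc3oc2=O)CC1c1ccccc1` gives 1920 nM. Compound 3 holds the lowest number of the three, and both gaps, to compound 1 and to compound 2, lie beyond the scatter. Compound 4 `NC(=O)C1CCN(CC(=O)N2N=C(c3cc4ccccc4oc3=O)CC2c2ccccc2)CC1` carries the change (4-carbamoylpiperidin-1-yl in place of isobutylamino on a saturated chain carbon bound to a carbonyl carbon). Within the data shown here, no measured pair shows this change, so its effect is unknown. Because compound 3 gives 1920 nM as the lowest number in this assay, the expectation for compound 4 is a number near that mark or modestly higher, not beyond the scatter. The estimate for compound 4 is 2600 nM, range 900 nM to 7500 nM. The expected step is a 1.4-fold higher number from compound 3 to compound 4 (0.13 log units; within the scatter).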

Compound 4, half-maximal inhibitory concentration: 8310 nM
The estimate for compound 4 lay 3.2-fold (0.50 log units) below the measured number, and the stated range ends below it.
By their numbers in this assay, from the lowest: compound 3; then compounds 4 and 1 (each within the scatter of the next); then compound 2.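

In this assay the saturated chain carbon bound to a carbonyl carbon proves sensitive to its substituent: 4-carbamoylpiperidin-1-yl in place of isobutylamino gives a 4.3-fold higher number from compound 3 to compound 4 (0.64 log units; beyond the scatter) on the shared core. Among these compounds, this is the first one-place comparison, and it favours isobutylamino over the larger ring-bearing group. No available data explain the shift.

From the compounds shown here alone, whether the higher number tracks the ring or the carbamoyl group remains open. Unsubstituted piperidin-1-yl or morpholin-4-yl at this place would help separate the two.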